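Phenyl for Ethyl on the Ester Chain of Compound 1

This account rests on a few compounds, and the source may have more. Where it says the series, first, only, none or still open, it means among the compounds named here.

Compound 1, `CCCOC(=O)Nc1ccc([Se]C#N)cc1`, was tested in a functional assay on HT-29 cells (Homo sapiens) for cytotoxicity, read by MTT assay, with a stated time of 72 h (a higher number here means a weaker inhibitor of growth, a lower number a stronger inhibitor of growth), and gave 51900 nM. Among the three measured compounds it holds the highest number, but its companions sit close: compound 2, `CCCCCCOC(=O)Nc1ccc([Se][Se]c2ccc(NC(=O)OCCCCCC)cc2)cc1`, gives 42600 nM in this assay, and compound 3, `O=C(Nc1ccc([Se][Se]c2ccc(NC(=O)OCc3ccc([N+](=O)[O-])cc3)cc2)cc1)OCc1ccc([N+](=O)[O-])cc1`, gives 46300 nM. Both of those gaps to compound 1 lie within the usual scatter of repeated measurements, so the three cannot be ordered by these numbers alone.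

Compound 4, `N#C[Se]c1ccc(NC(=O)OCc2ccccc2)cc1`, has not yet been measured. It differs from compound 1 in one place: phenyl in place of ethyl on a saturated chain carbon bound to an oxygen next to a carbonyl group. The rest of the shared core is untouched. Among the measured compounds shown here, no pair of measured compounds shows this particular change, so there is no measured step to lean on. Compounds 2 and 3 carry ester chains of quite different kind and still land near one another and near compound 1, which gives no sign that this part of the molecule moves the number far.

The step from compound 1 to compound 4 is therefore expected to be small, a 1.3-fold lower number from compound 1 to compound 4 (0.11 log units; within the scatter), at most a modest shift and possibly none beyond the scatter. In this assay compound 4 is estimated at 40000 nM, with a likely range from 15000 nM to 100000 nM.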

Compound 4, concentration for total growth inhibition: 41200 nM
Compound 4: the middle estimate sits 1.0-fold (0.01 log units) below what was measured, and the stated range covers the measured number.
By their numbers in this assay, from the lowest: compounds 4, 2, 3 and 1 (each within the scatter of the next).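

In this assay, among the compounds shown here, the exchange of ethyl for phenyl on a saturated chain carbon bound to an oxygen next to a carbonyl group gives the first measured step in this set between two compounds that differ in one place (a 1.3-fold lower number from compound 1 to compound 4 (0.10 log units; within the scatter)). For the compounds shown here, this shows directly that, on the core of compound 1, this place accepts one six-membered aromatic ring of carbon only in place of ethyl with no shift that can be told from the scatter, which the earlier compounds, lacking any such step, could not show. No measurement at hand bears on why the number stays within the scatter through this change.

The compounds shown leave open whether any other group at this place, such as an amine, a carboxylic acid or a much longer chain, would move the number beyond the scatter. They also leave open whether a phenyl carrying an amine or a carboxylic acid would read as this plain phenyl does in this assay on the same core.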